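This account rests on a few compounds, and the source may have more. Where it says the series, first, only, none or still open, it means among the compounds named here.

Measured in a functional assay on A2780 cells (Homo sapiens) for antiproliferative activity, read by CellTiter-Glo, with a stated time of 4 days; a lower number here means a stronger inhibitor, a higher number a weaker inhibitor:
- compound 1 `Nc1ccc(CNC(=O)Nc2ccc(CN3C(=O)c4ccccc4C3=O)cc2)cn1`: 7 nM
- compound 2 `O=C(NCc1cccnc1)Nc1ccc(CN2C(=O)c3ccccc3C2=O)cc1`: 100 nM
- compound 3 `O=C(/C=C/c1cccnc1)Nc1ccc(CN2C(=O)c3ccccc3C2=O)cc1`: "not determined" (no result reported)

Compound 3 has no number to start from, so its place in this assay is open: the entry for compound 3 reads "not determined" (no result reported). The next structure, compound 4 `O=C(Nc1ccc(CN2C(=O)c3ccccc3C2=O)cc1)[C@H]1C[C@@H]1c1cccnc1`, changes the group on the carbonyl carbon: a group of 9 heavy atoms (8 carbon, 1 nitrogen; one three-membered non-aromatic ring of carbon only, one six-membered aromatic ring with 1 hetero atom) in place of a group of 8 heavy atoms (7 carbon, 1 nitrogen; one six-membered aromatic ring with 1 hetero atom), on a carbonyl carbon. The 2-(pyridin-3-yl)ethenyl group leaves, and the entering group adds a three-membered carbon ring and 2 defined stereocentres.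

Going by the values given here, the only measured step is large, a 14-fold higher number from compound 1 to compound 2 (1.15 log units; beyond the scatter), but it concerns hydrogen in place of amino on an aromatic carbon, not the group on the carbonyl carbon. It shows that the series can move strongly, yet it gives no size or direction for this change. Among the compounds with values here, no step from compound 3 can therefore be expected. The closest reference is compound 2 at 100 nM, which also lacks the amino group of compound 1, so the range is kept wide.

In this assay the expected value for compound 4 is 50 nM, with an estimated range of 8 nM to 300 nM.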

Compound 4, half-maximal inhibitory concentration: 27 nM
Beside the measured number, compound 4's estimate is 1.9-fold (0.27 log units) above it; the measured number falls inside the stated range.
By their numbers in this assay, from the lowest: compound 1; then compound 4; then compound 2.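

In this assay the carbonyl position accepts a group with a three-membered carbon ring in place of the group of compound 2, with a 3.7-fold lower number from compound 2 to compound 4 (0.57 log units; beyond the scatter) as the change, while the step from compound 3 cannot be read. The same group does not match the group of compound 1, as a 3.9-fold higher number from compound 1 to compound 4 (0.59 log units; beyond the scatter) shows, so the amino-bearing group of compound 1 keeps the lowest number of the three measured compounds. No measurement at hand accounts for either step.

Still open, as far as these compounds go, is whether the two defined stereocentres of compound 4 matter, and whether an amino group on its pyridine ring would lower the number as it does from compound 2 to compound 1. A longer carbon chain in place of the three-membered ring also remains untested in the compounds shown.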